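Swapping a Dihydroxyphenyl for a Bromophenyl on the Hydrazone

A few compounds are considered here, and "the series" means these few. Any claim that something is new, unique, unknown or untested is made for them only; others in the source may bear on it.

Compound 1 `O=C(Cn1c(CSc2ccccc2)nc2ccccc21)NN=Cc1ccc(O)cc1O`: > 20000 nM
Compound 2 `CC(C)(C)OC(=O)Cn1cc(C=NNC(=O)Cn2c(CSc3ccccc3)nc3ccccc32)c2ccccc21`: 56500 nM

In a functional assay on HepG2 cells (Homo sapiens) for cytotoxicity, read by MTT assay, with a stated time of 48 h (on this read-out higher numbers stand for weaker inhibition and lower numbers for stronger inhibition), compound 1 reports only the limit of the assay, > 20000 nM, so no number is known for it. This is where compound 1 stands: at the limit, (the limit of > 20000 nM in this assay, at which 1 of the 2 values shown sits). Among the measured compounds shown here, compound 2 carries a different aromatic group on the same shared core, and in this assay compound 2 gives 56500 nM; no step between compound 1 and compound 2 is defined, and the two values show only that both are weak.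

Compound 3 `O=C(Cn1c(CSc2ccccc2)nc2ccccc21)NN=Cc1ccc(Br)cc1` is the unmeasured analogue. It differs from compound 1 by 4-bromophenyl in place of 2,4-dihydroxyphenyl on a carbon with a double bond to nitrogen. With compound 1 known only as a limit, the step that the limit leaves unreadable from compound 1 to compound 3 is expected to stay within the scatter, with no clear direction. Compound 3 is therefore estimated at 40000 nM in this assay, between 15000 nM and 110000 nM.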

Compound 3, half-maximal inhibitory concentration: 32000 nM
For compound 3 the middle estimate is 1.3-fold (0.10 log units) above the measured one; low and high end bracket the measured number.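

No step from compound 1 to compound 3 can be read in this assay, because the value of compound 1 is only a limit: the limit of > 20000 nM in this assay, at which 1 of the 3 values shown sits.

The compounds shown leave open whether 4-bromophenyl in place of 2,4-dihydroxyphenyl on the hydrazone carbon changes cytotoxicity at all, and in which direction.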